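Hydroxy for methoxy on the shared core: expected growth inhibition

The source may hold more compounds than are shown below. What is called first, only, known or untested is meant among the compounds shown, and "the series" means these compounds.

Three compounds of the shared core have numbers in a functional assay on cells (Leukemia cell, Homo sapiens) for cytotoxicity, read by sulforhodamine B assay, with a stated time of 48 h; a higher number here means a weaker inhibitor of growth, a lower number a stronger inhibitor of growth. Compound 1 `COc1ccc(OC)c(-c2cc(-c3ccccc3)nn2-c2ccc(S(N)(=O)=O)cc2)c1` gives 6940 nM. Compound 2 `COc1ccc(OC)c(-c2cc(-c3ccccc3)nn2-c2ccc(S(=O)(=O)NC(C)=O)cc2)c1` gives 7400 nM, and compound 3 `COc1ccc(OC)c(-c2cc(-c3ccc(Cl)cc3)nn2-c2ccc(S(=O)(=O)NC(C)=O)cc2)c1` gives 7450 nM. Compound 2 lies among three numbers that all fall within the scatter of one another; its nearest neighbour is compound 3 and its furthest is compound 1, and neither distance reaches beyond the scatter. The two measured steps are a 1.1-fold higher number from compound 1 to compound 2 (0.03 log units; within the scatter) and a 1.0-fold higher number from compound 2 to compound 3 (0.00 log units; within the scatter); neither moves the number beyond the scatter.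

Compound 4 `CC(=O)NS(=O)(=O)c1ccc(-n2nc(-c3ccccc3)cc2-c2cc(O)ccc2O)cc1` is not yet measured. It differs from compound 2 in one place: 2,5-dihydroxyphenyl in place of 2,5-dimethoxyphenyl on an aromatic carbon. The 2,5-dihydroxyphenyl enters on an aromatic carbon of the five-membered aromatic ring with two nitrogens, next to the ring nitrogen. Neither measured step touches this group: one changes the sulfonamide nitrogen, the other the phenyl. The numbers therefore give no basis for a shift beyond the scatter in either direction, and the range must stay wide. The estimate for compound 4 is 7000 nM, between 2500 nM and 20000 nM, which means an expected step of a 1.1-fold lower number from compound 2 to compound 4 (0.02 log units; within the scatter).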

Compound 4, concentration for 50% growth inhibition: 93600 nM
Compound 4: the middle estimate sits 13-fold (1.13 log units) below what was measured; measured number above the stated range.
By their numbers in this assay, from the lowest: compounds 1, 2 and 3 (each within the scatter of the next); then compound 4.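

In this assay, 2,5-dihydroxyphenyl in place of 2,5-dimethoxyphenyl on the aromatic carbon of the five-membered ring gives a 13-fold higher number from compound 2 to compound 4 (1.10 log units; beyond the scatter), so compound 4 is a weaker inhibitor of growth than compound 2. This is the only step shown that passes beyond the scatter, whereas the sulfonamide nitrogen change gives a 1.1-fold higher number from compound 1 to compound 2 (0.03 log units; within the scatter) and the chloro change gives a 1.0-fold higher number from compound 2 to compound 3 (0.00 log units; within the scatter). The series therefore responds at this aryl position, and the response runs towards weaker inhibition when both methoxy groups are replaced, with the entering group carrying 2 hydrogen-bond donors where the leaving group carries 0.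

Among these compounds, the single pair cannot separate the two oxygen positions, so it remains open whether one hydroxy beside one methoxy would give the same loss, and whether an amine, a carboxylic acid or a longer alkoxy chain such as ethoxy at these positions would keep the number of compound 2 or move it further. No measurement in hand bears on the reason for the loss.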